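The source may report more compounds than this note shows. Statements on the series, on what has been measured and on what is new or still open speak of the compounds shown alone.

Compound 1 `COc1ccccc1-n1nncc1CN1C(=O)C2(C(C#N)=C(N)Oc3c2c2nc4ccccc4nc2c2ccccc32)c2ccccc21`: > 50000 nM
Compound 2 `N#CC1=C(N)Oc2c(c3nc4ccccc4nc3c3ccccc23)C12C(=O)N(Cc1cnnn1-c1ccc(Cl)c(Cl)c1)c1ccccc12`: > 50000 nM
Compound 3 `Cc1cccc(-n2nncc2CN2C(=O)C3(C(C#N)=C(N)Oc4c(N)cc5nc6ccccc6nc5c43)c3ccccc32)c1`: > 50000 nM

All three compounds were tested in a functional assay on MCF7 cells (Homo sapiens) for antiproliferative activity, read by MTT assay, with a stated time of 48 h; on this read-out higher numbers stand for weaker inhibition and lower numbers for stronger inhibition. Every entry in the list above is a limit of the assay and not a measured number. Compound 3 therefore stands exactly where compounds 1 and 2 stand, at the limit of > 50000 nM in this assay, at which 3 of the 3 values shown sit, and none of the three can be placed above or below the others.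

The compound not yet measured is compound 4 `N#CC1=C(N)Oc2c(N)cc3nc4ccccc4nc3c2C12C(=O)N(Cc1cnnn1-c1ccc([N+](=O)[O-])cc1)c1ccccc12`. It differs from compound 3 in one place: 4-nitrophenyl in place of 3-methylphenyl on an aromatic nitrogen.

Only one single-point step has been measured among these compounds, a step that the two limits leave unreadable from compound 1 to compound 2. That step also changes the group on the aromatic nitrogen, but both ends sit at the limit, so its size cannot be read and it offers no guide to the direction or magnitude of the present change. With compound 3 itself at the limit, there is no number from which a step could be counted.

On this evidence, compound 4 is expected to land where compound 3 does, so the step of a number no higher from compound 3 to compound 4 (the limit leaves the size open) is estimated to be none beyond the scatter. Compound 4 is estimated at 50000 nM, with a range from 20000 nM to 100000 nM, most likely reported as a limit again.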

Compound 4, half-maximal inhibitory concentration: > 50000 nM
Compound 4: only a limit was reported (the forecaster's own chance of this, stated with the estimate: 80%); the middle value sits exactly at the limit.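

The step from compound 3 to compound 4, 4-nitrophenyl in place of 3-methylphenyl, cannot be read, since both results in this assay are limits of the assay and not measured numbers: the limit of > 50000 nM in this assay, at which 4 of the 4 values shown sit.

The compounds shown leave open how the groups on the aromatic nitrogen rank against one another, and which structural change, if any, would give a measurable value.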